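The compounds below may be only part of what the source reports. "The series", "measured", "known", "first", "only" and "open" are said of these compounds alone.

Three compounds share the core of compound 1 `O=C(C1CC1)N1CCc2nc(C#Cc3ccccc3)sc2C1` and differ only in the group on a carbonyl carbon. In an assay on HEK293 cells for positive allosteric modulation of metabotropic glutamate receptor 5 (Homo sapiens), read by FLIPR, with a stated time of 1 h (on this read-out lower numbers stand for an effect already at smaller amounts and higher numbers for an effect only at larger amounts of compound), compound 1 reports only a limit, > 10000 nM. Compound 2 `O=C(C1CCC(F)(F)CC1)N1CCc2nc(C#Cc3ccccc3)sc2C1` gives 70 nM in this assay. Compound 3 `CC1CCC(C(=O)N2CCc3nc(C#Cc4ccccc4)sc3C2)CC1` gives 190 nM in this assay, the highest of the two numbers shown, with compound 2 nearest: a 2.7-fold higher number from compound 2 to compound 3 (0.43 log units; beyond the scatter). Compound 4 `O=C(N1CCCC1)N1CCc2nc(C#Cc3ccccc3)sc2C1` carries the change (pyrrolidin-1-yl in place of 4-methylcyclohexyl on a carbonyl carbon). Among the compounds with values here, two measured steps bear on this: an at least 52-fold lower number from compound 1 to compound 3 (1.72 log units; beyond the scatter), where cyclopropyl gave way to a six-membered ring, and a 2.7-fold higher number from compound 2 to compound 3 (0.43 log units; beyond the scatter). With a five-membered ring entering in place of the six-membered one, a number higher than that of compound 3 is expected, by an 11-fold higher number from compound 3 to compound 4 (1.02 log units; beyond the scatter). Compound 4 is therefore estimated at 2000 nM, within 400 nM to 10000 nM.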

Compound 4, half-maximal effective concentration: 9.8 nM
Compound 4: the middle estimate sits 200-fold (2.31 log units) above what was measured, and the stated range ends above it.
By their numbers in this assay, from the lowest: compound 4; then compound 2; then compound 3. At a limit, above all of these: compound 1.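

At this carbonyl carbon, pyrrolidin-1-yl, a smaller ring attached through its nitrogen, outperforms both six-membered rings, with a 19-fold lower number from compound 3 to compound 4 (1.29 log units; beyond the scatter) and a 7.1-fold lower number from compound 2 to compound 4 (0.85 log units; beyond the scatter). Cyclopropyl in compound 1 gives only a limit, so ring size alone does not order these compounds, and an at least 1000-fold lower number from compound 1 to compound 4 (3.00 log units; beyond the scatter) is a bound rather than an exact size: the limit of > 10000 nM in this assay, at which 1 of the 4 values shown sits.

The compounds shown leave open whether the gain comes from the ring nitrogen or from the five-membered ring. Cyclopentyl and piperidin-1-yl at this place would separate those two features.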